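From chloro to trifluoromethyl on compound 3

This account rests on a few compounds, and the source may have more. Where it says the series, first, only, none or still open, it means among the compounds named here.

Of the compounds shown here, three sharing one core have been measured in an ADME assay on 184B5 cells (Homo sapiens) for cytotoxicity, read by sulforhodamine B assay, with a stated time of 48 h; on this read-out lower numbers stand for stronger inhibition of growth and higher numbers for weaker inhibition of growth. Compound 1 `NC(=S)N/N=C1/C(=O)N(CN2CCN(c3ccnc4cc(Cl)ccc34)CC2)c2cc(Cl)ccc21` gives 41300 nM, compound 2 `NC(=S)N/N=C1/C(=O)N(CN2CCN(c3ccnc4cc(Cl)ccc34)CC2)c2cc(Br)ccc21` gives 13100 nM, and compound 3 `NC(=S)N/N=C1/C(=O)N(CN2CCN(c3ccnc4cc(Cl)ccc34)CC2)c2ccccc21` gives 28800 nM. Compound 3 therefore sits level with compound 1 within the scatter, as shown by a 1.4-fold lower number from compound 1 to compound 3 (0.16 log units; within the scatter), while compound 2 lies apart from it, with a 2.2-fold higher number from compound 2 to compound 3 (0.34 log units; beyond the scatter).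

The next compound, compound 4 `NC(=S)N/N=C1/C(=O)N(CN2CCN(c3ccnc4cc(C(F)(F)F)ccc34)CC2)c2ccccc21`, has not yet been measured. It carries trifluoromethyl in place of chloro on an aromatic carbon, a change counted as trifluoromethyl in place of chloro on an aromatic carbon. Within the data shown here, none of the measured steps touches this carbon, since each swaps bromo, chloro or hydrogen on a different aromatic carbon, and no measured compound carries trifluoromethyl. These steps can therefore guide the expectation only loosely. Among the measured compounds shown here, the largest of them, the one leading to compound 2, is still modest at a 3.2-fold lower number from compound 1 to compound 2 (0.50 log units; beyond the scatter), so only a small move is expected in this assay, with no clear direction. The estimated step is a 1.1-fold lower number from compound 3 to compound 4 (0.04 log units; within the scatter), and nothing beyond the scatter is expected. Compound 4 is estimated at 26000 nM, with an expected range from 10000 nM to 65000 nM.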

Compound 4, concentration for 50% growth inhibition: 20200 nM
Compound 4: middle estimate off by 1.3-fold (0.11 log units), on the high side; the range from low to high includes it.
By their numbers in this assay, from the lowest: compounds 2, 4, 3 and 1 (each within the scatter of the next, the first and the last beyond it).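

Among these compounds, compound 4 gives the first measured step on this aromatic carbon, which lies on the six-membered aromatic ring of carbon only, meta to a fused ring and para to a fused ring; the earlier steps all fell on a different aromatic carbon. In this assay, replacing chloro with trifluoromethyl, a group with more heavy atoms and no hydrogen-bond donors or acceptors, gives a 1.4-fold lower number from compound 3 to compound 4 (0.15 log units; within the scatter), so this single exchange leaves compound 4 level with compound 3, and the assay does not separate the two groups at this position on the shared core. No measurement shown here explains this result.

The two groups tested at this position leave open whether an amine or a carboxylic acid there would give a step beyond the scatter, since neither chloro nor trifluoromethyl marks how far this carbon can respond. Also open, from the compounds shown here alone, is whether trifluoromethyl would leave the number equally unmoved alongside the bromo or chloro on the other aromatic carbon, as compound 4 carries hydrogen there.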